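Methoxy for chloro on the core of compound 1

The source may report more compounds than this note shows. Statements on the series, on what has been measured and on what is new or still open speak of the compounds shown alone.

compound 1 `COc1ccc(NC(=O)C(=O)c2cn(C(C)C)c3c(Cl)cccc23)cn1` gives 10200 nM
compound 2 `CCn1cc(C(=O)C(=O)Nc2ccnc(OC)c2)c2ccccc21` gives 4180 nM
compound 3 `COc1ccc(NC(=O)C(=O)c2cn(C(C)C)c3ccccc23)cc1` gives 181 nM

In a functional assay on FaDu cells (Homo sapiens) for cytotoxicity, read by MTT assay, with a stated time of 72 h (a lower number here means that less compound is tolerated, a higher number that more compound is tolerated), compound 1 stands highest of the three, and compound 2 and compound 3 both lie lower, beyond the scatter. The next compound to be measured, compound 4 `COc1ccc(NC(=O)C(=O)c2cn(C(C)C)c3c(OC)cccc23)cn1`, keeps the core of compound 1 and changes one group: methoxy in place of chloro on an aromatic carbon. Within the data shown here, no measured pair shows this exchange on its own, so the data fix the size of the step only loosely. In this assay a modest step toward a lower number is expected, since compound 1 at 10200 nM sits at the top of the measured range, while compound 3 at 181 nM shows how far down the series reaches. The range stays wide and also allows for no change beyond the scatter. For compound 4 the expected value is 5000 nM, with an estimated range from 1200 nM to 15000 nM. The estimate amounts to an expected 2.0-fold lower number from compound 1 to compound 4 (0.31 log units; beyond the scatter).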

Compound 4, concentration lethal to 50% of the cells: > 10000 nM
Compound 4: only a limit was reported (the forecaster's own chance of this, stated with the estimate: 10%); middle value at least 2.0-fold (0.30 log units) from the limit.
By their numbers in this assay, from the lowest: compound 3; then compound 2; then compound 1.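

In this assay compound 4 gives > 10000 nM, which is a limit and not a number. Among these compounds, no step from compound 1 to compound 4 can be read. The compounds shown leave open whether methoxy in place of chloro on an aromatic carbon changes the number at all, and in which direction.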